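Trifluoromethyl in Place of Ethyl on the Aromatic Ring

The source may hold more compounds than are shown below. What is called first, only, known or untested is meant among the compounds shown, and "the series" means these compounds.

Compound 1 `O=C(O)CCCSCCN1C(=O)SC[C@@H]1/C=C/[C@@H](O)Cc1ccccc1`: in an assay on CHO cells for displacement of a labelled ligand from prostaglandin E2 receptor EP1 subtype (Mus musculus), read by scintillation counting, with a stated time of 20 min (a lower number here means a stronger inhibitor, a higher number a weaker inhibitor), compound 1 reaches only > 10000 nM, a limit of the assay and not a number.
Compound 2 `CCc1cccc(C[C@H](O)/C=C/[C@H]2CSC(=O)N2CCSCCCC(=O)O)c1`: in this assay compound 2 gives 4600 nM.

Compound 2 holds the only true number shown. The value of compound 1 is a limit (the limit of > 10000 nM in this assay, at which 1 of the 2 values shown sits). The step of an at least 2.1-fold lower number from compound 1 to compound 2 (0.33 log units; beyond the scatter) came with ethyl in place of hydrogen. Compound 3 `O=C(O)CCCSCCN1C(=O)SC[C@@H]1/C=C/[C@@H](O)Cc1cccc(C(F)(F)F)c1` differs from compound 2 by trifluoromethyl in place of ethyl on an aromatic carbon. Among the compounds with values here, only that one measured step bears on this change, so a step of similar size toward a lower number in this assay is expected, though one within the scatter remains possible. For compound 3 the expected value is 3000 nM, within 800 nM to 12000 nM, an estimated step of a 1.5-fold lower number from compound 2 to compound 3 (0.19 log units; within the scatter).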

Compound 3, inhibition constant: > 10000 nM
Compound 3: a limit, no number (the forecaster's own chance of this, stated with the estimate: 20%); at least 3.3-fold (0.52 log units) between middle value and limit.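

Compound 3 gives only a limit, not a number, in this assay: the limit of > 10000 nM in this assay, at which 2 of the 3 values shown sit.
Trifluoromethyl in place of ethyl brings an at least 2.1-fold higher number from compound 2 to compound 3 (0.33 log units; beyond the scatter), so on this aromatic carbon the weaker inhibition comes with trifluoromethyl and the gain seen with ethyl does not carry over. The step between compound 1 and compound 3 cannot be read.

From the compounds shown here alone, how far compound 3 lies past its limit stays open. So does whether propyl, a longer chain, or methoxy on the same aromatic carbon would give a lower number than ethyl.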